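The source may report more compounds than this note shows. Statements on the series, on what has been measured and on what is new or still open speak of the compounds shown alone.

Measured in a functional assay on HL-60 cells (Homo sapiens) for antiproliferative activity, read by MTT assay, with a stated time of 24 h; on this read-out higher numbers stand for weaker inhibition and lower numbers for stronger inhibition:
- Compound 1 `CNC(=O)c1ccccc1Oc1nc(Nc2ccccc2F)ncc1Br` gives > 50000 nM, a limit.
- Compound 2 `CNC(=O)c1ccccc1Oc1nc(Nc2ccc(Cl)cc2F)ncc1Br` gives > 50000 nM, a limit.
- Compound 3 `O=[N+]([O-])c1ccc(Oc2nc(Nc3ccc(Cl)cc3)ncc2Br)c(F)c1` gives > 50000 nM, a limit.

Compound 3 therefore has no numerical value to serve as a starting point. Its position is shared by the whole set: the limit of > 50000 nM in this assay, at which 3 of the 3 values shown sit.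

Compound 4 `O=[N+]([O-])c1ccc(Oc2nc(Nc3ccc(Br)cc3)ncc2Br)c(F)c1` differs from compound 3 by a single exchange on the 4-chlorophenyl group: bromo in place of chloro on an aromatic carbon. This places bromo in place of chloro on an aromatic carbon, para to a large group.

The closest measured step is a step that the two limits leave unreadable from compound 1 to compound 2, which is chloro in place of hydrogen on an aromatic carbon. Within the data shown here, it gives no usable size, and no measured step covers the exchange of chloro for bromo. No shift beyond the scatter in this assay is therefore expected, and compound 4 is expected to remain at the limit.

The expected change is a number no higher from compound 3 to compound 4 (the limit leaves the size open).

For compound 4 the estimated value is 50000 nM, with an expected range from 20000 nM to 100000 nM.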

Compound 4, half-maximal inhibitory concentration: > 50000 nM
Compound 4: only a limit was reported (the forecaster's own chance of this, stated with the estimate: 75%); the middle value lies on the limit itself.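

In this assay, no step can be read between compound 3 and compound 4, the exchange of chloro for bromo, with both reported only as limits: the limit of > 50000 nM in this assay, at which 4 of the 4 values shown sit.

The compounds shown leave open what any numerical value in this assay would be and which single exchanges would change it.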